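The source may hold more compounds than are shown below. What is called first, only, known or untested is meant among the compounds shown, and "the series" means these compounds.

Compound 2 `CN1CCN(c2nc3ccccc3[nH]2)CC1` stands at the edge of what the numbers show: in a functional assay on ileum for inhibition of histamine H1 receptor (Cavia porcellus) (on this read-out lower numbers stand for stronger inhibition and higher numbers for weaker inhibition), compound 2 gives > 3000 nM, which is a limit of the assay and not a measured number. As far as these compounds go, it therefore sits at the limit of > 3000 nM in this assay, at which 1 of the 2 values shown sits, and how far beyond that it lies is unknown. Compound 1 `CCSCCCn1c(N2CCN(C)CC2)nc2ccccc21` in this assay gives 530 nM. Among the compounds with values here, the only measured step, an at least 5.6-fold higher number from compound 1 to compound 2 (0.75 log units; beyond the scatter), comes from hydrogen in place of 3-(ethylsulfanyl)propyl on the aromatic nitrogen of the shared core.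

Compound 3 `CCCn1c(N2CCN(C)CC2)nc2ccccc21` differs from compound 2 by propyl in place of hydrogen on an aromatic nitrogen. This returns a chain, propyl rather than 3-(ethylsulfanyl)propyl, to the same aromatic nitrogen, so the measured step bears on it in reverse. The expected step of an at least 2.5-fold lower number from compound 2 to compound 3 (0.39 log units; beyond the scatter) is a move to a lower number, likely beyond the scatter, though the limit on compound 2 leaves its size uncertain. The estimate for compound 3 in this assay is 1200 nM, with a range from 400 nM to 3500 nM.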

Compound 3, half-maximal inhibitory concentration: 380 nM
The estimate for compound 3 lay 3.2-fold (0.50 log units) above the measured number; measured number outside the range, below it.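

Propyl on the aromatic nitrogen gives an at least 7.8-fold lower number from compound 2 to compound 3 (0.89 log units; beyond the scatter), so in this assay a chain without ethylsulfanyl is enough for a step of this kind. As far as these compounds go, compound 2 carries a limit of the assay and not a measured number, so the full size of that step stays unknown: the limit of > 3000 nM in this assay, at which 1 of the 3 values shown sits. Taking ethylsulfanyl off the chain gives a 1.4-fold lower number from compound 1 to compound 3 (0.14 log units; within the scatter), so this read-out does not separate the two chains.

From the compounds shown here alone, it remains open whether a shorter chain, such as methyl or ethyl, on the same aromatic nitrogen would keep the lower number, or whether a chain ending in an amine or a hydroxyl group would shift it. The compounds shown also leave open whether the step holds when the ring atom that bears the group of 7 heavy atoms carries another group.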